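The source may report more compounds than this note shows. Statements on the series, on what has been measured and on what is new or still open speak of the compounds shown alone.

Working notes on the series in a functional assay on PC-3 cells (Homo sapiens), read by MTT assay, with a stated time of 48 h; a higher number here means a weaker inhibitor, a lower number a stronger inhibitor. Among the measured compounds shown here, compound 1 `CCOC(=O)CN(C)C(=O)c1ccc(C(CC)(CC)c2ccc(OCC(O)C(C)(C)C)c(C)c2)n1CC` gives 25500 nM, and compound 2 `CCN(CC)CCCNC(=O)c1ccc(C(CC)(CC)c2ccc(OCC(O)C(C)(C)C)c(C)c2)n1CC` gives 2500 nM, the lower of the two numbers so far. Compound 3 `CCn1c(C(=O)NCCN)ccc1C(CC)(CC)c1ccc(OCC(O)C(C)(C)C)c(C)c1` shares the core of compound 2 and differs at the end of the chain: amino in place of (diethylamino)methyl on a saturated chain carbon, two bonds along the chain from an amide-type nitrogen. For the measured compounds named here, no measured pair isolates this change. Going by the values given here, the one measured step, a 10-fold lower number from compound 1 to compound 2 (1.01 log units; beyond the scatter), is large but swaps the whole group on the carbonyl carbon, so it bears only indirectly and shows that this part of the structure can move the number. A small rise is therefore expected, which may not clear the scatter: the expected step is a 1.8-fold higher number from compound 2 to compound 3 (0.26 log units; within the scatter). The estimate for compound 3 is 4500 nM, with an expected range of 1500 nM to 13000 nM.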

Compound 3, half-maximal inhibitory concentration: 940 nM
Compound 3: the middle estimate sits 4.8-fold (0.68 log units) above what was measured; measured number below the stated range.
By their numbers in this assay, from the lowest: compound 3; then compound 2; then compound 1.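

In this assay, the (diethylamino)methyl group on a saturated chain carbon, two bonds along the chain from an amide-type nitrogen, is not required for activity: amino in its place gives a 2.7-fold lower number from compound 2 to compound 3 (0.42 log units; beyond the scatter) and a number beyond the scatter. Among the compounds shown here, compound 2 therefore no longer marks the low end of the series, and the group on the carbonyl carbon can move the number further, with (2-aminoethyl)amino in place of ((ethoxycarbonyl)methyl)(methyl)amino giving a 27-fold lower number from compound 1 to compound 3 (1.43 log units; beyond the scatter) as the largest step so far. Nothing at hand explains either step.

The step from compound 2 to compound 3 shortens the chain and removes the ethyl groups together, so the two changes stay unseparated. A (3-aminopropyl)amino or a (2-(diethylamino)ethyl)amino group on the same carbonyl carbon would pull them apart.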